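From a long chain to pyridin-3-yl on the carbonyl

The source may report more compounds than this note shows. Statements on the series, on what has been measured and on what is new or still open speak of the compounds shown alone.

Values so far in an ADME assay on MRC5 cells (Homo sapiens) for cytotoxicity, read by neutral red uptake, with a stated time of 24 h (on this read-out lower numbers stand for stronger inhibition and higher numbers for weaker inhibition), are these:
- Compound 1 `CC(C)c1cc2c3c(c1OC(=O)CCl)OC(=O)[C@@]31CCCC(C)(C)[C@@H]1CC2` gives 130000 nM as a measured number
- Compound 2 `CCCC(=O)Oc1c(C(C)C)cc2c3c1OC(=O)[C@@]31CCCC(C)(C)[C@@H]1CC2` gives 44400 nM as a measured number
- Compound 3 `CCCCCCCCCCCC(=O)Oc1c(C(C)C)cc2c3c1OC(=O)[C@@]31CCCC(C)(C)[C@@H]1CC2` gives > 1000000 nM which is a limit of the assay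

Compound 3 has no exact number and stands at the limit of > 1000000 nM in this assay, at which 1 of the 3 values shown sits, on this scale.

In compound 4 `CC(C)c1cc2c3c(c1OC(=O)c1cccnc1)OC(=O)[C@@]31CCCC(C)(C)[C@@H]1CC2` the change is pyridin-3-yl in place of undecyl on a carbonyl carbon and the rest of the molecule stays the same.

Going by the values given here, the steps that bear on this change all alter the same chain. They are an at least 22-fold higher number from compound 2 to compound 3 (1.35 log units; beyond the scatter) and an at least 7.6-fold higher number from compound 1 to compound 3 (0.88 log units; beyond the scatter) with the smaller 2.9-fold lower number from compound 1 to compound 2 (0.47 log units; beyond the scatter) between the two shorter chains. Among the compounds with values here, no compound with a ring on this carbonyl has been measured, so any forecast stays loose. The forecast leans on compound 1 (130000 nM) and compound 2 (44400 nM) as the nearest measured partners in size.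

The expected move is an at least 12-fold lower number from compound 3 to compound 4 (1.09 log units; beyond the scatter) by this estimate.

The estimated value for compound 4 is 80000 nM in this assay with an expected range (20000 nM to 350000 nM).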

Compound 4, half-maximal inhibitory concentration: 296000 nM
Estimate against measurement, compound 4: 3.7-fold (0.57 log units) below, within the range that was stated.
By their numbers in this assay, from the lowest: compound 2; then compound 1; then compound 4. At a limit, above all of these: compound 3.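

Pyridin-3-yl is the first ring shown at this place, on a carbonyl carbon, and in this assay it gives a result that the chains alone did not predict: it sits apart from both short-chain compounds, with a 6.7-fold higher number from compound 2 to compound 4 (0.82 log units; beyond the scatter) and a 2.3-fold higher number from compound 1 to compound 4 (0.36 log units; beyond the scatter). Replacing the long chain with this ring gives an at least 3.3-fold lower number from compound 3 to compound 4 (0.52 log units; beyond the scatter), so the ring lies on the weaker side of the short chains but on the stronger side of the undecyl compound. That last step is only a bound, as compound 3 has a limit rather than an exact number: the limit of > 1000000 nM in this assay, at which 1 of the 4 values shown sits.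

From the compounds shown here alone, whether the ring nitrogen matters stays open, and a plain phenyl ring on this carbonyl would test it. Also open, going by these compounds, is where the numbers climb between propyl and undecyl, which a hexyl chain would begin to show.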